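A few compounds are considered here, and "the series" means these few. Any claim that something is new, unique, unknown or untested is made for them only; others in the source may bear on it.

Compound 1 `O=C(NC1CCCCC1)Oc1cccc(C2=NCCO2)c1` and compound 2 `O=C(NC1CCCCC1)Oc1cccc(C2=N[C@@H](Cc3ccccc3)CO2)c1` share the same carbamate core and differ only on the five-membered ring. For the measured compounds named here, in an assay (strain Wistar) for inhibition of Fatty-acid amide hydrolase 1 (Rattus norvegicus), read by scintillation counting (on this read-out higher numbers stand for weaker inhibition and lower numbers for stronger inhibition), compound 1 gives 1.2 nM, while compound 2 gives 2100 nM, the highest of the two numbers recorded; the single known step, a 1800-fold higher number from compound 1 to compound 2 (3.24 log units; beyond the scatter), is large and lies well beyond the scatter.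

Compound 3 `COC(=O)[C@H]1COC(c2cccc(OC(=O)NC3CCCCC3)c2)=N1` is the next change: methoxycarbonyl in place of benzyl on a saturated ring carbon. Going by the values given here, no measured pair shows a methoxycarbonyl at this position, so the only guide is the step from compound 1 to compound 2, which shows that placing a benzyl on that saturated ring carbon raised the number sharply. Methoxycarbonyl is a smaller group, so compound 3 is expected to fall somewhere between the two measured numbers rather than beyond them, meaning a step of a 5.3-fold lower number from compound 2 to compound 3 (0.72 log units; beyond the scatter) is estimated in this assay. Among the compounds with values here, on that basis compound 3 is estimated at 400 nM, with a plausible range from 40 nM to 4000 nM; the uncertainty is wide because only one step of compound 1 to compound 2 is available.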

Compound 3, half-maximal inhibitory concentration: 90 nM
Estimate against measurement, compound 3: 4.4-fold (0.65 log units) above; the measured number falls inside the stated range.
By their numbers in this assay, from the lowest: compound 1; then compound 3; then compound 2.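

The size of the penalty at this saturated ring carbon depends strongly on which group sits there: methoxycarbonyl in place of benzyl gives a 23-fold lower number from compound 2 to compound 3 (1.37 log units; beyond the scatter) and recovers much of the inhibition lost with benzyl. Even so, a bare hydrogen on this carbon remains the best of the three, with methoxycarbonyl in place of hydrogen giving a 75-fold higher number from compound 1 to compound 3 (1.88 log units; beyond the scatter), so both groups shown here weaken inhibition, though to very different degrees. No measurement shown here explains why the numbers move this way.

Benzyl and methoxycarbonyl differ at once in heavy-atom count, in the presence of an aromatic ring and in hydrogen-bond acceptors, so these compounds cannot show which of those differences matters. As far as these compounds go, a methyl, a hydroxymethyl or a carboxylic acid on the same ring carbon could help separate them, and it remains open whether any group at this position can match the hydrogen of compound 1.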